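The compounds below may be only part of what the source reports. "The series", "measured", "known", "first", "only" and "open" are said of these compounds alone.

Compound 1 `C=CC1=C(C(=O)NCc2ccccc2)C(c2ccc(OC)c(OC)c2)OC1` gives > 100000 nM in a functional assay on QGY7701 cells (Homo sapiens) for cytotoxicity, read by MTT assay, with a stated time of 24 h (a higher number here means a weaker inhibitor, a lower number a stronger inhibitor), which is a limit of the assay and not a number.
Compound 2 `C=CC1=C(C(=O)NCc2ccccc2)C(c2ccc(OC)cc2)OC1` gives > 100000 nM in this assay, again only a limit.
Compound 3 `C=CC1=C(C(=O)O)C(c2ccc(OC)cc2)OC1` gives > 100000 nM in this assay, also a limit.

All three measured compounds share one core, and none of them reaches a measurable reading in this assay. Compound 2 therefore stands at the limit of the assay, with nothing to separate it from compound 1 or compound 3. The step that the two limits leave unreadable from compound 1 to compound 2 and the step that the two limits leave unreadable from compound 2 to compound 3 cannot be read, since the limit of > 100000 nM in this assay, at which 3 of the 3 values shown sit, applies to every value shown.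

Compound 4 `C=CC1=C(C(=O)Nc2ccc(OCC)cc2)C(c2ccc(OC)cc2)OC1` differs from compound 2 in one place: 4-ethoxyphenyl in place of benzyl on an amide-type nitrogen. Among the compounds with values here, no measured step bears on this change, and no measured step has a readable size at all, so there is nothing that points to a gain or a loss beyond the scatter. The expectation for the step from compound 2 to compound 4 is thus a number no higher from compound 2 to compound 4 (the limit leaves the size open), meaning no readable change is expected. On that basis compound 4 is estimated at 100000 nM in this assay, with an expected range from 30000 nM to 300000 nM, and most likely the assay will again report only a limit.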

Compound 4, half-maximal inhibitory concentration: > 100000 nM
Compound 4: only a limit was reported; the forecaster's own chance of this, stated with the estimate: 80%; the middle value lies on the limit itself.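

The step between compound 2 and compound 4 cannot be read, since each gives only a limit and no number: the limit of > 100000 nM in this assay, at which 4 of the 4 values shown sit.

The compounds shown leave open whether any change to the shared core would bring a measurable reading in this assay and how far these four compounds truly differ from one another.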